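A few compounds are considered here, and "the series" means these few. Any claim that something is new, unique, unknown or untested is made for them only; others in the source may bear on it.

Compound 1 `C[C@@H](O)[C@H]1C(=O)N2C(C(=O)OCOC(=O)OC(C)(C)C)=C(S[C@@H]3CN[C@H](C(=O)Nc4cccc(C(=O)O)c4)C3)[C@H](C)[C@H]12` was tested in an ADME assay on a cell-free system (plasma, Homo sapiens) for metabolic stability, read by LC-MS, with a stated time of 60 min, at 37 degrees C, tested at 50 uM (on this read-out lower numbers stand for a less stable compound and higher numbers for a more stable compound), where compound 1 gives 40%. Among the compounds with values here, that is the only number available: compound 2 `CC(C)OC(=O)C1=C(S[C@@H]2CN[C@H](C(=O)Nc3cccc(C(=O)O)c3)C2)[C@H](C)[C@@H]2[C@@H]([C@@H](C)O)C(=O)N12` was also put through this assay, and compound 2 is recorded there as "not determined" (no result reported), so no result exists for it and compound 1 stands alone and cannot be ranked against another measured compound. Compound 3 `C[C@@H](O)[C@H]1C(=O)N2C(C(=O)OCOC(=O)OC(C)(C)C)=C(S[C@@H]3CN[C@H](C(=O)Nc4cccc(C(=O)OCOC(=O)OC(C)(C)C)c4)C3)[C@H](C)[C@H]12` differs from compound 1 in one place: ((tert-butoxycarbonyl)oxy)methyl in place of hydrogen on an oxygen next to a carbonyl group. Within the data shown here, no step between measured compounds is known here, so nothing measured shows how such a change shifts the read-out. A step downward, larger than the usual scatter, is expected from compound 1 to compound 3 in this assay a number 20 percentage points lower from compound 1 to compound 3 (beyond the scatter). Compound 3 is therefore estimated to give 20%, with a likely range from 5% to 45%.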

Compound 3, percent of the compound remaining: 67%
The estimate for compound 3 lay 47 percentage points below the measured number; the measured number lies above the stated range.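

Until now, nothing measured showed how this position responds to a change. In this assay, ((tert-butoxycarbonyl)oxy)methyl in place of hydrogen on an oxygen next to a carbonyl group gives a number 27 percentage points higher from compound 1 to compound 3 (beyond the scatter), so for this pair the added group of 9 heavy atoms moves the read-out towards the more stable side rather than the less stable one. No available evidence explains why the number moves this way.

This is a single step at a single position, so it sets no general rule. The compounds shown leave open whether a small methyl group or a longer carbon chain on the same oxygen would shift the number in the same direction, and what an amine in place of the hydroxy would do.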